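Replacing 1-bromonaphthalen-2-yl with 3-chlorophenyl on the shared core

This account rests on a few compounds, and the source may have more. Where it says the series, first, only, none or still open, it means among the compounds named here.

In a functional assay on HeLa cells (Homo sapiens) for antiproliferative activity, with a stated time of 5 days (on this read-out lower numbers stand for stronger inhibition and higher numbers for weaker inhibition), compound 1 `CC1OC2(C=CC(=O)C=C2)N(c2nc(-c3cccc4ccccc34)nn2-c2ccccc2)C1=O` gives 110 nM and compound 2 `O=C1C=CC2(C=C1)OCC(=O)N2c1nc(-c2ccc3ccccc3c2Br)nn1-c1ccccc1` stands at 290 nM as the higher and so weaker of the two numbers, a gap beyond the usual scatter. Compound 3 `O=C1C=CC2(C=C1)OCC(=O)N2c1nc(-c2cccc(Cl)c2)nn1-c1ccccc1` carries 3-chlorophenyl in place of 1-bromonaphthalen-2-yl on an aromatic carbon and so holds one aromatic ring there instead of two. Among the compounds with values here, no measured pair shows this change alone, so the expectation is loose. In this assay a weakening is expected, with an estimated step of a 2.4-fold higher number from compound 2 to compound 3 (0.38 log units; beyond the scatter) that lies somewhat beyond the scatter. Compound 3 is estimated at 700 nM within a range from 200 nM to 2500 nM on this evidence.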

Compound 3, half-maximal inhibitory concentration: 45.3 nM
The estimate for compound 3 lay 15-fold (1.19 log units) above the measured number; the whole stated range lies above it.
By their numbers in this assay, from the lowest: compound 3; then compound 1; then compound 2.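

In this assay, the position on the five-membered aromatic ring with 3 nitrogen proves not to need the second aromatic ring: 3-chlorophenyl in place of 1-bromonaphthalen-2-yl gives a 6.4-fold lower number from compound 2 to compound 3 (0.81 log units; beyond the scatter), a step beyond the scatter. At this position, the smaller of the two groups goes with the stronger inhibition, though this rests on one pair of compounds. No evidence bearing on the cause of this step is at hand. The compounds shown leave open whether the chlorine matters at all, and how a plain phenyl, or a phenyl bearing an amine or a carboxylic acid, would behave here in this assay.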